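A few compounds are considered here, and "the series" means these few. Any claim that something is new, unique, unknown or untested is made for them only; others in the source may bear on it.

Compound 1 `O=C(O)Cc1sc(C(c2ccc(F)cc2)c2ccc(F)cc2)nc1-c1cccc(F)c1` gives 80% in an in vitro functional assay on HEK285-7 cells for antagonist activity at prostaglandin D2 receptor 2 (Homo sapiens), read by BRET and beta-arrestin recruitment; a lower number here means a smaller maximal response, a higher number a larger maximal response. Compound 2 `O=C(O)Cc1sc(C(c2ccc(F)cc2)c2ccc(F)cc2)nc1-c1cc(F)cc(F)c1` gives 80%, and compound 3 `O=C(O)Cc1sc(C(c2ccc(F)cc2)c2ccc(F)cc2)nc1-c1cn[nH]c1` gives 80%, level with both of them. Compound 4 `O=C(O)Cc1sc(C(c2ccc(F)cc2)c2ccc(F)cc2)nc1-c1ccncc1` has not yet been measured; its change from compound 3 is pyridin-4-yl in place of 1H-pyrazol-4-yl on an aromatic carbon. The measured steps that bear on this are the two that exchange the group at the same place on the shared core: no change at the digits printed from compound 1 to compound 3 (within the scatter) and no change at the digits printed from compound 2 to compound 3 (within the scatter), both within the scatter. Three different groups there have thus left the largest response unchanged, so the step of no change at the digits printed from compound 3 to compound 4 (within the scatter) is expected to stay within the scatter as well. Compound 4 is therefore estimated to give 80%, within a range from 68% to 92%.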

Compound 4, largest response reached (reported as efficacy), in percent of the reference or control that the assay uses: 80%
Compound 4: the middle estimate sits on the measured number at the digits printed; measured number inside the range.
By their numbers in this assay, from the lowest: compounds 1, 2, 3 and 4 (each within the scatter of the next).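

In this assay there is no change at the digits printed from compound 3 to compound 4 (within the scatter), so a six-membered aromatic ring with 0 hydrogen-bond donors can take the place of the five-membered 1H-pyrazol-4-yl, which has 1. Against the fluorinated phenyl groups there is likewise no change at the digits printed from compound 2 to compound 4 (within the scatter) and no change at the digits printed from compound 1 to compound 4 (within the scatter), which extends the flat result to a pyridine nitrogen at this position. No supporting evidence explains this flat result.
Going by these compounds, all four compounds carry an aromatic ring here, so it remains open whether a morpholine, an amine or a longer alkyl chain would shift the largest response.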